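The compounds below may be only part of what the source reports. "The series", "measured", "known", "first", "only" and "open" are said of these compounds alone.

Measured compounds in a functional assay on HT-29 cells (Homo sapiens) for antiproliferative activity, read by MTT assay, with a stated time of 72 h; on this read-out lower numbers stand for stronger inhibition and higher numbers for weaker inhibition:
- compound 1, `Cn1ccc2c(Oc3ccc(NC(=O)c4cc5cccnc5n(-c5ccccc5)c4=O)cc3)ccnc21`: 620 nM
- compound 2, `Cn1ccc2c(Oc3ccc(NC(=O)c4cc5cccnc5n(-c5ccc(Cl)cc5)c4=O)cc3)ccnc21`: 730 nM
- compound 3, `Cn1ccc2c(Oc3ccc(NC(=O)c4cc5cccnc5n(-c5ccc(F)c(Cl)c5)c4=O)cc3)ccnc21`: 1210 nM

All three compounds share one core and differ only in the aryl group carried on an aromatic nitrogen. Their numbers in this assay lie close together: the step of a 1.2-fold higher number from compound 1 to compound 2 (0.07 log units; within the scatter), the step of a 2.0-fold higher number from compound 1 to compound 3 (0.29 log units; within the scatter) and the step of a 1.7-fold higher number from compound 2 to compound 3 (0.22 log units; within the scatter) are each within the scatter, so compound 3 cannot be set apart from compound 1 or compound 2 on these data.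

Compound 4, `Cn1ccc2c(Oc3ccc(NC(=O)c4cc5cccnc5n(-c5ccc(Br)cc5F)c4=O)cc3)ccnc21`, carries the change (4-bromo-2-fluorophenyl in place of 3-chloro-4-fluorophenyl on an aromatic nitrogen), that is, 4-bromo-2-fluorophenyl in place of 3-chloro-4-fluorophenyl on an aromatic nitrogen of the shared core. For the measured compounds named here, the steps that bear on this change are the two earlier exchanges of the aryl group on that nitrogen, a 2.0-fold higher number from compound 1 to compound 3 (0.29 log units; within the scatter) and a 1.7-fold higher number from compound 2 to compound 3 (0.22 log units; within the scatter), together with the single halogen exchange a 1.2-fold higher number from compound 1 to compound 2 (0.07 log units; within the scatter); none of them reached beyond the scatter. A further reshuffling of two halogens on the same ring is therefore expected to give a step of no more than the usual scatter in this assay, with no clear direction.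

Compound 4 is estimated at 1000 nM, with a range from 400 nM to 2500 nM, which means an expected step of a 1.2-fold lower number from compound 3 to compound 4 (0.08 log units; within the scatter).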

Compound 4, half-maximal inhibitory concentration: 2580 nM
The estimate for compound 4 lay 2.6-fold (0.41 log units) below the measured number; measured number above the stated range.
By their numbers in this assay, from the lowest: compounds 1, 2 and 3 (each within the scatter of the next); then compound 4.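

In this assay, the aryl group on this aromatic nitrogen now makes a difference that can be read: the exchange for 4-bromo-2-fluorophenyl gives modest steps beyond the scatter against all three earlier compounds (a 2.1-fold higher number from compound 3 to compound 4 (0.33 log units; beyond the scatter); a 3.5-fold higher number from compound 2 to compound 4 (0.55 log units; beyond the scatter); a 4.2-fold higher number from compound 1 to compound 4 (0.62 log units; beyond the scatter)), whereas the exchanges among compound 1, compound 2 and compound 3 all stayed within it. The position is therefore not indifferent to the aryl group it carries, and compound 4 is the only one of the four that can be set apart from all the others, with the highest number and so the weakest inhibition of the set. Nothing available explains why this halogen pair on the ring raises the number.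

Going by these compounds, compound 4 brings in the bromine and the 2-fluoro arrangement together, so it remains open which of them carries the step, a question that 4-bromophenyl and 2-fluorophenyl groups on the same nitrogen would separate. On these data alone, it also remains open how this position would respond to something other than a halogen on the phenyl ring, such as an amine or a carboxylic acid.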